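The source may report more compounds than this note shows. Statements on the series, on what has been measured and on what is new or still open speak of the compounds shown alone.

Measured in a functional assay on DU-145 cells (Homo sapiens) for antiproliferative activity, read by WST assay, with a stated time of 3 days; on this read-out lower numbers stand for stronger inhibition and higher numbers for weaker inhibition:
- compound 1 `CCCOc1c(-c2cc(OC)c(OC)c(OC)c2)oc2ccccc2c1=O`: 2800 nM
- compound 2 `CCN(CC)CCCOc1c(-c2cc(OC)c(OC)c(OC)c2)oc2ccccc2c1=O`: > 50000 nM (a limit)

Compound 2 stands at the limit of > 50000 nM in this assay, at which 1 of the 2 values shown sits. That is a limit and not a number, so any step away from compound 2 has an open starting point.

Compound 3 `CCCN(CCC)CCCCCOc1c(-c2cc(OC)c(OC)c(OC)c2)oc2ccccc2c1=O` carries 2-(dipropylamino)ethyl in place of diethylamino on a saturated chain carbon, three bonds along the chain from an oxygen on an aromatic ring. The same difference reads 3-(diethylamino)propyl to 5-(dipropylamino)pentyl.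

Within the data shown here, only one measured step bears on this, and it was made at the same place: an at least 17-fold higher number from compound 1 to compound 2 (1.25 log units; beyond the scatter). Among the measured compounds shown here, this step is large, but it is a different change, and no measured step covers a swap of one amino chain for another. Compound 3 still carries an amino group, as compound 2 does, so the expectation stays on the weak side of compound 1 at 2800 nM. In this assay the expected change is an at least 5.0-fold lower number from compound 2 to compound 3 (0.69 log units; beyond the scatter), a modest move towards lower numbers, and a second reading at the limit remains possible. For compound 3 the estimate is 10000 nM, with an expected range of 2000 nM to 50000 nM.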

Compound 3, half-maximal inhibitory concentration: 24200 nM
Compound 3: the middle estimate sits 2.4-fold (0.38 log units) below what was measured; measured number inside the range.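

In this assay compound 2 stands only at a limit and not at a number: the limit of > 50000 nM in this assay, at which 1 of the 3 values shown sits.

Measured against that limit, replacing 3-(diethylamino)propyl with 5-(dipropylamino)pentyl gives an at least 2.0-fold lower number from compound 2 to compound 3 (0.31 log units; beyond the scatter), and compound 3 is the first of the amino-bearing chains shown with a measured number, so an amino group at this place does not on its own put a compound at the limit. The amino-free chain of compound 1 still keeps the lower number, with an 8.6-fold higher number from compound 1 to compound 3 (0.94 log units; beyond the scatter), so the new chain recovers only part of what an at least 17-fold higher number from compound 1 to compound 2 (1.25 log units; beyond the scatter) gave up.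

Compound 3 differs from compound 2 in both chain length and the alkyl groups on nitrogen, and the compounds shown do not separate these two changes; 5-(diethylamino)pentyl or 3-(dipropylamino)propyl would do so. As far as these compounds go, whether the trend continues with a longer chain, or how a ring amine such as piperidine or a carboxylic acid at the chain end would read, also stays open.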